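Swapping a hydroxypropyl amine for a methylpyrazole amine

The source may report more compounds than this note shows. Statements on the series, on what has been measured and on what is new or still open speak of the compounds shown alone.

Measured so far:
compound 1 `C[C@@H](CO)Nc1ncc(Cl)c(-c2cc3n(c2)C(=O)N([C@H](CO)c2cccc(Cl)c2)C3)n1`: 81 nM
compound 2 `C[C@H](CO)Nc1ncc(Cl)c(-c2cc3n(c2)C(=O)N([C@H](CO)c2cccc(Cl)c2)C3)n1`: "not active" (no number reported)

In a functional assay on COLO 205 cells (Homo sapiens) for antiproliferative activity, read by luminescence, with a stated time of 72 h (a lower number here means a stronger inhibitor, a higher number a weaker inhibitor), compound 1 gives 81 nM. Compound 2 `C[C@H](CO)Nc1ncc(Cl)c(-c2cc3n(c2)C(=O)N([C@H](CO)c2cccc(Cl)c2)C3)n1` is reported in this assay only as "not active" (no number reported), with no number attached, so its standing rests on that word alone. Within the data shown here, the two compounds are otherwise the same, and the fact that compounds 1 and 2 differ only in the configuration as drawn is the only point on which they differ; no measured step connects them, so their values can merely be set side by side.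

Compound 3 `Cn1nccc1Nc1ncc(Cl)c(-c2cc3n(c2)C(=O)N([C@H](CO)c2cccc(Cl)c2)C3)n1` follows from compound 2 by one change: 1-methyl-1H-pyrazol-5-yl in place of 1-(hydroxymethyl)ethyl on a nitrogen on an aromatic ring. The stereocentre that separates compound 1 from compound 2 is thereby removed altogether, and a small aromatic ring takes the place of an open chain bearing a hydroxyl.

Among the measured compounds shown here, no measured step of this kind exists, so the size of the move in this assay can only be expected, not computed. Starting from a compound without a number, the expectation is a step toward stronger inhibition, beyond the usual scatter. Compound 3 is estimated at 200 nM, within a range from 20 nM to 3000 nM.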

Compound 3, half-maximal inhibitory concentration: 31.9 nM
Compound 3: the middle estimate sits 6.3-fold (0.80 log units) above what was measured; the measured number falls inside the stated range.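

In this assay the change from the open chain to the aromatic ring reads as a 2.5-fold lower number from compound 1 to compound 3 (0.40 log units; beyond the scatter), so 1-methyl-1H-pyrazol-5-yl on this nitrogen is not merely accepted but gives the lower number of the two measured values. This place therefore does not need the hydroxyl of 1-(hydroxymethyl)ethyl, nor any stereocentre in the group, for activity in this assay to persist. Compound 2 has no number, so no step from it can be read, but the earlier pair made activity look tied to one drawn arrangement of the chain, with compound 1 at 81 nM and compound 2 reported as "not active", and compound 3 shows that a group without that arrangement can also work here, the contrast resting on one fact: the fact that compounds 1 and 2 differ only in the configuration as drawn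

The step replaces the chain, the hydroxyl and the stereocentre in one move and brings in a ring and its methyl, so the compounds shown cannot say which of these parts accounts for the lower number. They also leave open how this place responds to a pyrazole without the methyl, to a six-membered pyridine ring, or to a longer chain ending in a hydroxyl.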